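The source may report more compounds than this note shows. Statements on the series, on what has been measured and on what is new or still open speak of the compounds shown alone.

Measured so far in an ADME assay on microsomes from liver (Rattus norvegicus), read by LC-MS, using NADPH, with a stated time of 10 min, tested at 0.5 uM; a lower number here means that less of the compound is left, a higher number that more of the compound is left
compound 1 `Cc1nc2cc(-c3cccc(-c4ccccc4)c3)nn2c(-c2cc(F)c3c(c2C)CCCO3)c1[C@H](OC(C)(C)C)C(=O)O` gives 96%
compound 2 `COc1ccccc1-c1cccc(-c2cc3nc(C)c([C@H](OC(C)(C)C)C(=O)O)c(-c4cc(F)c5c(c4C)CCCO5)n3n2)c1` gives 99%
compound 3 `Cc1nc2cc(-c3cccc(-c4ccccc4F)c3)nn2c(-c2cc(F)c3c(c2C)CCCO3)c1[C@H](OC(C)(C)C)C(=O)O` gives 89%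

Compound 3 stands at 89% and lies within the scatter of the other two compounds, with a number 7 percentage points lower from compound 1 to compound 3 (within the scatter) and a number 10 percentage points lower from compound 2 to compound 3 (within the scatter) as the steps that reach it. The next change leads to compound 4 `Cc1nc2cc(-c3cccc(-c4ccncc4)c3)nn2c(-c2cc(F)c3c(c2C)CCCO3)c1[C@H](OC(C)(C)C)C(=O)O` and reads pyridin-4-yl in place of 2-fluorophenyl on an aromatic carbon in full. In short, it places pyridin-4-yl in place of 2-fluorophenyl on an aromatic carbon. Among the compounds with values here, the steps that bear on it all alter the same aryl group: the two above and a number 3 percentage points higher from compound 1 to compound 2 (within the scatter) as well. All three stay within the scatter, but none of them tests a ring nitrogen in that group, so the transfer to compound 4 is uncertain. No shift beyond the scatter is expected, and the estimated size is a number 3 percentage points higher from compound 3 to compound 4 (within the scatter) for now. Compound 4 is expected at 92% (estimated range 80% to 100%) in this assay once tested.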

Compound 4, percent of the compound remaining: 94%
The estimate for compound 4 lay 2 percentage points below the measured number; measured number inside the range.
By their numbers in this assay, from the lowest: compounds 3, 4, 1 and 2 (each within the scatter of the next).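

In this assay, a ring nitrogen in this aryl group, which sits on an aromatic carbon of a six-membered aromatic ring of carbon only, leaves the read-out within the scatter of all three comparators: a number 5 percentage points higher from compound 3 to compound 4 (within the scatter), a number 5 percentage points lower from compound 2 to compound 4 (within the scatter) and a number 2 percentage points lower from compound 1 to compound 4 (within the scatter). Pyridin-4-yl therefore reads the same here as phenyl, 2-fluorophenyl and 2-methoxyphenyl, so no aryl group among these four compounds separates from the others in this assay. No measurement at hand accounts for this.

On these data alone, whether a non-aromatic group at this place, such as a morpholine or a longer chain ending in an amine, would move the number beyond the scatter remains open. As far as these compounds go, the tert-butoxy group and the carboxylic acid are common to all four compounds, so their contribution to the read-out also remains open.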